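Changing the Aromatic Substituent: From Dimethylamino to Nitro

The source may report more compounds than this note shows. Statements on the series, on what has been measured and on what is new or still open speak of the compounds shown alone.

Compound 1 `COc1ccc(/C=N\NC(=S)NC(C)(C)CCC[C@](C)(O)[C@@H]2CC=C(C)CC2)cc1`: in a functional assay on OVCAR-3 cells (Homo sapiens) for cytotoxicity, read by sulforhodamine B assay (on this read-out higher numbers stand for weaker inhibition of growth and lower numbers for stronger inhibition of growth), compound 1 gives 15800 nM.
Compound 2 `CC1=CC[C@@H]([C@@](C)(O)CCCC(C)(C)NC(=S)N/N=C\c2ccc(N(C)C)cc2)CC1`: in this assay compound 2 gives only a limit, > 100000 nM.

Compound 2 therefore has no exact number in this assay; what is known is the limit of > 100000 nM in this assay, at which 1 of the 2 values shown sits, so its growth inhibition is weaker than the assay can quantify. Among the compounds with values here, the one measured step, an at least 6.3-fold higher number from compound 1 to compound 2 (0.80 log units; beyond the scatter), shows that exchanging the group on the aromatic ring can move the read-out by a clearly visible amount.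

Compound 3 `CC1=CC[C@@H]([C@@](C)(O)CCCC(C)(C)NC(=S)N/N=C\c2ccccc2[N+](=O)[O-])CC1` is the next variation on the same core. Its difference from compound 2 is 2-nitrophenyl in place of 4-(dimethylamino)phenyl on a carbon with a double bond to nitrogen. Within the data shown here, this is again a change of the substituent on the aromatic ring, so the measured step from compound 1 to compound 2 is the only guide, and it says such changes can matter. Since compound 2 sits at the limit, a move in the direction of stronger inhibition, back toward the region of compound 1, is expected for compound 3, though a result that again stays at the limit is quite possible. The expected step is an at least 2.8-fold lower number from compound 2 to compound 3 (0.45 log units; beyond the scatter). For compound 3 the estimate in this assay is 35000 nM, with a range from 10000 nM to 100000 nM.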

Compound 3, concentration for total growth inhibition: 16200 nM
For compound 3 the middle estimate is 2.2-fold (0.33 log units) above the measured one; measured number inside the range.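

In this assay, the exchange for 2-nitrophenyl gives an at least 6.1-fold lower number from compound 2 to compound 3 (0.79 log units; beyond the scatter), so the shared core can still inhibit growth when 4-(dimethylamino)phenyl is absent, and the group on the carbon with a double bond to nitrogen decides much of the outcome. The comparison with 4-methoxyphenyl gives a 1.0-fold higher number from compound 1 to compound 3 (0.01 log units; within the scatter), which means that two different aromatic groups cannot be told apart on this read-out, and compound 2 is the one of the three that stands apart from the others. The true size of the step to compound 3 remains unknown because compound 2 has only a limit and no exact number: the limit of > 100000 nM in this assay, at which 1 of the 3 values shown sits.

Within the data shown here, with only three aromatic groups to compare, it remains open whether the result depends more on the identity of the group or on where it sits on the ring, a question that 4-nitrophenyl, 2-methoxyphenyl or plain phenyl could help to settle. From the compounds shown here alone, it is also open how a ring bearing a chlorine atom, or a pyridine ring in place of the benzene ring, would read.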